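This account rests on a few compounds, and the source may have more. Where it says the series, first, only, none or still open, it means among the compounds named here.

Measured compounds:
- compound 1, `COC(=O)C1=C(C)NC(c2nccs2)=NC1(C)c1ccc(Cl)cc1`, in a physicochemical assay for solubility, read by HPLC, in phosphate buffer, at pH 6.5; on this read-out higher numbers stand for higher solubility and lower numbers for lower solubility: 14 ug/mL
- compound 2, `COC(=O)C1=C(C)NC(c2nccs2)=NC1(C)c1ccc(C#N)cc1`: 87 ug/mL
- compound 3, `COC(=O)C1=C(CN2CCCCC2)NC(c2nccs2)=NC1(C)c1ccc(F)cc1`: 282 ug/mL

Compound 3 gives the highest of the three numbers in this assay. Its nearest neighbour is compound 2, and the gap between them lies beyond the scatter; compound 1 is furthest away, again beyond the scatter. Among the compounds with values here, the only single-point step among the measured compounds is a 6.2-fold higher number from compound 1 to compound 2 (0.79 log units; beyond the scatter), a change on the aromatic ring.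

Compound 4, `COC(=O)C1=C(CN2CCCS2(=O)=O)NC(c2nccs2)=NC1(C)c1ccc(F)cc1`, differs from compound 3 in a different part of the molecule: a group of 7 heavy atoms (3 carbon, 1 nitrogen, 2 oxygen, 1 sulfur; one five-membered non-aromatic ring with 2 hetero atoms) in place of a group of 6 heavy atoms (5 carbon, 1 nitrogen; one six-membered non-aromatic ring with 1 hetero atom), on a saturated chain carbon bound to a double-bonded ring carbon. Within the data shown here, no measured step touches this part of the structure, so the step from compound 1 to compound 2 does not bear on it, and nothing measured here tells which way the number should move or by how much. The estimate for compound 4 therefore rests on the value of compound 3 alone and carries a wide range. Compound 4 is expected to give about 100 ug/mL in this assay, somewhere between 25 ug/mL and 400 ug/mL, an expected step of a 2.8-fold lower number from compound 3 to compound 4 (0.45 log units; beyond the scatter) that may or may not exceed the scatter.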

Compound 4, solubility: 125 ug/mL
Compound 4: middle estimate off by 1.3-fold (0.10 log units), on the low side, and the stated range covers the measured number.
By their numbers in this assay, from the lowest: compound 1; then compounds 2 and 4 (each within the scatter of the next); then compound 3.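

The swap of piperidin-1-yl for the five-membered ring with 2 hetero atoms, on a saturated chain carbon bound to a double-bonded ring carbon, gives in this assay a 2.3-fold lower number from compound 3 to compound 4 (0.35 log units; beyond the scatter), the first measured direction and size for a change in this part of the structure. The swap alters several things at once: the ring size, the hetero atoms, the hydrogen-bond acceptor count (1 in the group that leaves, 2 in the group that enters) and the 2 double bonds outside aromatic rings, so this single step cannot be assigned to any one of them. Nothing measured here says why the number moves.

A morpholine ring or a pyrrolidine ring at the same place, each differing from these two groups in a narrower way, would help separate the effect of ring size from that of the sulfur and its two oxygens. On these data alone, it also remains open whether the same swap would give a step of similar direction and size with chloro or cyano in place of the fluoro on the aromatic ring.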